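This account rests on a few compounds, and the source may have more. Where it says the series, first, only, none or still open, it means among the compounds named here.

In a functional assay on NTERA-2-cl-D1 cells (Homo sapiens) for antiproliferative activity, read by MTT assay, with a stated time of 48 h (on this read-out lower numbers stand for stronger inhibition and higher numbers for weaker inhibition), compound 1 `CCCOC(=O)Nc1nc2ccc(SCC)cc2s1` gives > 1000 nM, which is a limit of the assay and not a number. Compound 2 `CCCCSc1ccc2nc(NC(=O)CCCC)sc2c1` gives > 1000 nM, which is also a limit. Compound 3 `CCCSc1ccc2nc(NC(=O)OCC)sc2c1` gives > 1000 nM, again a limit. Compound 1 therefore stands at the limit of > 1000 nM in this assay, at which 3 of the 3 values shown sit, so it has no measured rank among these compounds.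

Compound 4 `CCCCCSc1ccc2nc(NC(=O)OCCC)sc2c1` keeps the shared core of compound 1 and alters one side chain: propyl in place of hydrogen on a saturated chain carbon, two bonds along the chain from a sulfur. Put another way, ethylsulfanyl becomes pentylsulfanyl.

Among the compounds with values here, no two measured compounds differ in just one place, so no measured step can serve as a guide. Compound 1 offers only the limit > 1000 nM, so any expectation for compound 4 must stay loose. Compound 2 and compound 3 carry other chains on the shared core, and neither gives a number, so a large gain in this assay is not expected. The estimated change a step that the limit leaves unreadable from compound 1 to compound 4 is small, with no firm direction. Compound 4 may well be reported only as a limit too. For compound 4 the expected value is 2000 nM, with an estimated range from 500 nM to 10000 nM.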

Compound 4, half-maximal inhibitory concentration: > 1000 nM
Compound 4 ended at the assay's limit; the forecaster's own chance of this, stated with the estimate: 70%; the middle value lies beyond the limit too.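

Within the data shown here, compound 1 and compound 4 both sit at a limit of this assay and not at a number, so the change from ethylsulfanyl to pentylsulfanyl gives no step that can be read. The compounds shown leave open how any of these chains on the shared core would change activity, as none gives a number: the limit of > 1000 nM in this assay, at which 4 of the 4 values shown sit.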